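The source may report more compounds than this note shows. Statements on the series, on what has been measured and on what is new or still open speak of the compounds shown alone.

Measured so far:
Compound 1, `O=C(CCCCCc1cccc(Br)c1)N1CCOC1=O`: 430 nM in an assay on HEK293 cells for inhibition of N-acylethanolamine-hydrolyzing acid amidase (Rattus norvegicus), read by LC-MS, with a stated time of 30 min; a higher number here means a weaker inhibitor, a lower number a stronger inhibitor
Compound 2, `O=C(CCCCCc1ccc(F)c(Cl)c1)N1CCOC1=O`: 26 nM in this assay

Compound 1 stands at the higher of the two numbers shown, and compound 2 sits well below it, a gap that goes beyond the usual scatter. The step to the unmeasured compound 3, `CSc1cccc(CCCCCC(=O)N2CCOC2=O)c1`, is a single swap on the ring: methylsulfanyl in place of bromo on an aromatic carbon. Among the measured compounds shown here, no pair of measured compounds differs by this exchange, so the size of its effect in this assay has no direct precedent here. Since no listed compound tells how methylsulfanyl compares with bromo, the expected step from compound 1 is small, with no clear direction beyond the scatter, although a modest move towards a lower number is the more likely side. On that basis compound 3 is estimated at 300 nM, within 80 nM to 1200 nM, which corresponds to an expected step of a 1.4-fold lower number from compound 1 to compound 3 (0.16 log units; within the scatter).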

Compound 3, half-maximal inhibitory concentration: 12800 nM
Estimate against measurement, compound 3: 43-fold (1.63 log units) below; measured number above the stated range.
By their numbers in this assay, from the lowest: compound 2; then compound 1; then compound 3.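

Putting methylsulfanyl in place of bromo gives a 30-fold higher number from compound 1 to compound 3 (1.47 log units; beyond the scatter) in this assay, the first step shown that isolates a single change on the ring. This aromatic carbon, meta to a large group, is therefore far from indifferent to what it carries: losing a bromine and gaining a carbon and a sulfur, with the rest of the core of compound 1 unchanged, is enough to weaken inhibition well beyond the scatter. No measurement at hand accounts for this step.

The compounds shown leave open how a methoxy, a methyl or a chloro alone on this carbon would compare with bromo and methylsulfanyl. They also leave open whether the same swap would carry a similar cost on a longer chain or with the ring substituents of compound 2.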